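The compounds below may be only part of what the source reports. "The series", "measured", "known", "first", "only" and "open" are said of these compounds alone.

In a functional assay on LoVo cells (Homo sapiens) for inhibition, read by MTT assay, with a stated time of 24 h (a lower number here means a stronger inhibitor, a higher number a weaker inhibitor), compound 3 (`CC1(C)[C@H]2CC[C@]1(C)N(Cc1cn(-c3ccc(C#N)cc3)nn1)C(=O)C2`) gives 90 nM, level with compound 1 (`CC1(C)[C@H]2CC[C@]1(C)N(Cc1cn(-c3cccc(F)c3)nn1)C(=O)C2`) at 90 nM, while compound 2 (`CC1(C)[C@H]2CC[C@]1(C)N(Cc1cn(-c3ccccc3Br)nn1)C(=O)C2`) at 60 nM lies within the scatter of both.

The step under consideration leads to compound 4 (`CC1(C)[C@H]2CC[C@]1(C)N(Cc1cn(-c3ccccc3C#N)nn1)C(=O)C2`): 2-cyanophenyl in place of 4-cyanophenyl on an aromatic nitrogen. Three measured steps at this same place bear on it, and all stay within the scatter: no change at the digits printed from compound 1 to compound 3 (within the scatter), a 1.5-fold lower number from compound 1 to compound 2 (0.18 log units; within the scatter) and a 1.5-fold higher number from compound 2 to compound 3 (0.18 log units; within the scatter). Compound 2, with its 2-bromophenyl group and 60 nM, is the nearest measured counterpart to the entering group. Among the compounds with values here, no measured pair shows the nitrile alone changing place, so this is a read-across from three compounds only.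

Given those small steps, no shift beyond the scatter is expected in this assay, and no direction is favoured. The expected step is a 1.1-fold lower number from compound 3 to compound 4 (0.05 log units; within the scatter). For compound 4 the estimate is 80 nM, with an expected range of 35 nM to 190 nM.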

Compound 4, half-maximal inhibitory concentration: 140 nM
For compound 4 the middle estimate is 1.8-fold (0.24 log units) below the measured one; measured number inside the range.
By their numbers in this assay, from the lowest: compounds 2, 1, 3 and 4 (each within the scatter of the next, the first and the last beyond it).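

In this assay, 2-cyanophenyl in place of 4-cyanophenyl gives a 1.6-fold higher number from compound 3 to compound 4 (0.19 log units; within the scatter), and 2-cyanophenyl in place of 3-fluorophenyl gives a 1.6-fold higher number from compound 1 to compound 4 (0.19 log units; within the scatter), so the place of the nitrile on the phenyl group makes no difference that can be read here. The new finding is cyano in place of bromo on an aromatic carbon, which gives a 2.3-fold higher number from compound 2 to compound 4 (0.37 log units; beyond the scatter), a modest step and the first at this position beyond the scatter, while the other changes at this position stay within it. Nothing available here accounts for this step.

On these data alone, whether an amine, a carboxylic acid or a methoxy group on the phenyl ring would give a larger step remains open. So does whether the step from bromo to cyano recurs in any other compound pair.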